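This account rests on a few compounds, and the source may have more. Where it says the series, first, only, none or still open, it means among the compounds named here.

Compound 1 `[O-]/[N+](=C\c1cn(-c2ccc(F)cc2)nn1)c1ccccc1`: 10200 nM
Compound 2 `[O-]/[N+](=C\c1cn(-c2ccc(C(F)(F)F)cc2)nn1)Cc1ccccc1`: > 100000 nM (a limit of the assay)
Compound 3 `CC(C)(C)/[N+]([O-])=C/c1cn(-c2ccc(F)cc2)nn1`: 58900 nM

In a functional assay on COLO 205 cells (Homo sapiens) for inhibition, read by MTT assay, with a stated time of 24 h (on this read-out lower numbers stand for stronger inhibition and higher numbers for weaker inhibition), compound 3 gives 58900 nM, the higher of the two numbers obtained. Among the measured compounds shown here, the only single-place step measured is a 5.8-fold higher number from compound 1 to compound 3 (0.76 log units; beyond the scatter). For compound 2 the assay returned only a limit, > 100000 nM. Compound 4 `CC(C)(C)/[N+]([O-])=C/c1cn(-c2ccc(C(F)(F)F)cc2)nn1` differs from compound 3 by trifluoromethyl in place of fluoro on an aromatic carbon. For the measured compounds named here, no measured step follows this same change; compound 2 also carries trifluoromethyl but differs from compound 1 in more than one place, so its limit of > 100000 nM in this assay, at which 1 of the 3 values shown sits, is only loose evidence that trifluoromethyl compounds sit high in this assay. A step no larger than modest, upward, is therefore expected for compound 4, a 1.4-fold higher number from compound 3 to compound 4 (0.16 log units; within the scatter). Compound 4 is estimated at 85000 nM, within 30000 nM to 250000 nM, with a fair chance that the assay again reports only a limit.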

Compound 4, half-maximal inhibitory concentration: 44700 nM
Compound 4: the middle estimate sits 1.9-fold (0.28 log units) above what was measured, within the range that was stated.
By their numbers in this assay, from the lowest: compound 1; then compounds 4 and 3 (each within the scatter of the next). At a limit, above all of these: compound 2.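

In this assay trifluoromethyl in place of fluoro on an aromatic carbon, para to a large group, gives a 1.3-fold lower number from compound 3 to compound 4 (0.12 log units; within the scatter) with tert-butyl on the double-bonded nitrogen, so the two groups are not separated here. The group on that nitrogen does register: tert-butyl in place of benzyl gives an at least 2.2-fold lower number from compound 2 to compound 4 (0.34 log units; beyond the scatter) with trifluoromethyl held on the aromatic carbon. The figure for compound 2 is a limit: the limit of > 100000 nM in this assay, at which 1 of the 4 values shown sits.

As far as these compounds go, whether an amine or a carboxylic acid at this aromatic carbon would read differently from fluoro and trifluoromethyl stays open. Also open, from the compounds shown here alone, is whether the same swap reads alike with phenyl on the nitrogen.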